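A few compounds are considered here, and "the series" means these few. Any claim that something is new, unique, unknown or untested is made for them only; others in the source may bear on it.

Three compounds have values in a functional assay on the whole organism for positive allosteric modulation, with Mus musculus as the target; a lower number here means that less compound is needed, a higher number that more compound is needed for the effect. Compound 1 `CCC(=O)N(c1ccc(Cl)c(Cl)c1)C1CCCC1O` gives 20 mg/kg, compound 3 `CCC(=O)N(c1cccc(C)c1)C1CCCC1N(C)C` gives 25 mg/kg; 25 mg/kg (2 entries), and compound 2 `CCC(=O)N(c1ccc(Cl)cc1)C1CCCCC1N(C)C` gives 14 mg/kg. Compound 2 thus lies within the scatter of compound 1, and no order can be drawn between them. Compound 4 `CCC(=O)N(c1ccc(C)cc1)C1CCCCC1N(C)C` departs from compound 2 at one place: methyl in place of chloro on an aromatic carbon, with methyl in place of chloro on an aromatic carbon, that is, 4-chlorophenyl to 4-methylphenyl. Among the compounds with values here, no measured pair isolates this change, so its size rests on the narrow spread of the three values alone. The expected change, a 1.3-fold higher number from compound 2 to compound 4 (0.11 log units; within the scatter), is none beyond the scatter. For compound 4 the estimated dose is 18 mg/kg, with an expected range of 8 mg/kg to 40 mg/kg.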

Compound 4, dose for half-maximal effect: > 50 mg/kg
Compound 4 ended at the assay's limit (the forecaster's own chance of this, stated with the estimate: 5%); middle value at least 2.7-fold (0.44 log units) away from the limit.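

Within the data shown here, this is the first comparison that differs in one place, and it shows that the change is not neutral in this assay: the step is an at least 3.5-fold higher number from compound 2 to compound 4 (0.55 log units; beyond the scatter). On this aromatic carbon, para to a large group, chloro and methyl are therefore not interchangeable, although both are single heavy atoms. The result for compound 4 is a limit of the assay, not a number, so the step fixes only a lower bound.

Going by these compounds, whether a group such as fluoro, methoxy, nitrile or an amine at this place would keep the dose of compound 2 remains open. On these data alone, whether the change carries over to the core of compound 1 also remains open.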